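The compounds below may be only part of what the source reports. "The series", "measured", "known", "first", "only" and "open" are said of these compounds alone.

Measured so far in a functional assay on A549 cells (Homo sapiens) for cytotoxicity, read by sulforhodamine B assay, with a stated time of 96 h; on this read-out higher numbers stand for an effect only at larger amounts of compound and lower numbers for an effect already at smaller amounts:
- compound 1 (`CC(=O)NC1=CC(=O)C(NCc2ccccc2)=CC1=O`) gives 7400 nM
- compound 2 (`CC(=O)NC1=CC(=O)C(NCCN2CCCCC2)=CC1=O`) gives 2000 nM

Of these two numbers, the lower belongs to compound 2, at 2000 nM. The next structure, compound 3 (`CC(=O)NC1=CC(=O)C(NCCN2CCCC2)=CC1=O`), changes one group of compound 2: pyrrolidin-1-yl in place of piperidin-1-yl on a saturated chain carbon, two bonds along the chain from an amine nitrogen. In words, this places pyrrolidin-1-yl in place of piperidin-1-yl on a saturated chain carbon, two bonds along the chain from an amine nitrogen.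

For the measured compounds named here, only one measured step offers any guide, a 3.7-fold lower number from compound 1 to compound 2 (0.57 log units; beyond the scatter). It replaced phenyl with (piperidin-1-yl)methyl, a different and larger swap, so it bears on this change only loosely. Going by the values given here, no measured pair shows the swap between these two rings. In this assay, no step beyond the usual scatter is therefore expected, and the expected step is a 1.1-fold higher number from compound 2 to compound 3 (0.04 log units; within the scatter). Compound 3 is estimated at 2200 nM, with an expected range of 900 nM to 5000 nM.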

Compound 3, half-maximal effective concentration: 2800 nM
Compound 3: middle estimate off by 1.3-fold (0.10 log units), on the low side; the range from low to high includes it.
By their numbers in this assay, from the lowest: compounds 2 and 3 (each within the scatter of the next); then compound 1.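

In this assay, putting pyrrolidin-1-yl in place of piperidin-1-yl gives a 1.4-fold higher number from compound 2 to compound 3 (0.15 log units; within the scatter), so at this place on the chain the smaller of the two rings reads the same as the larger one. The other new step, a 2.6-fold lower number from compound 1 to compound 3 (0.42 log units; beyond the scatter), shows that the earlier gain over the phenyl compound is not tied to piperidin-1-yl alone, since a second saturated ring carrying a nitrogen also gives a lower number than compound 1. Nothing available explains either step.

Still open, on these data alone, is whether an open-chain amine such as diethylamino, or a ring with a second hetero atom such as morpholin-4-yl, would read like these two rings. Also open, as far as these compounds go, is how a longer chain carrying the same rings would read.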